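The compounds below may be only part of what the source reports. "The series", "measured", "known", "first", "only" and "open" are said of these compounds alone.

Compound 3 `COc1cc(OC)c(-c2coc3cc(OCc4ccccc4C(F)(F)F)ccc3c2=O)cc1OC` gives 8550 nM in a functional assay on B16 cells (Mus musculus) for antiproliferative activity, read by MTT assay, with a stated time of 24 h (a lower number here means a stronger inhibitor, a higher number a weaker inhibitor), the highest of the three numbers in hand. Compound 1 `C#CCOc1ccc2c(=O)c(-c3cc(OC)c(OC)cc3OC)coc2c1` gives 4500 nM, and compound 2 `COc1ccc2c(=O)c(-c3cc(OC)c(OC)cc3OC)coc2c1` gives 5200 nM. The steps of a 1.9-fold higher number from compound 1 to compound 3 (0.28 log units; within the scatter) and a 1.6-fold higher number from compound 2 to compound 3 (0.22 log units; within the scatter) both stay within the scatter, as does a 1.2-fold higher number from compound 1 to compound 2 (0.06 log units; within the scatter), so no real difference among these three compounds has been established. Compound 4 `COc1cc(OC)c(-c2coc3cc(OCc4ccccc4Br)ccc3c2=O)cc1OC` differs from compound 3 in one place: bromo in place of trifluoromethyl on an aromatic carbon. Within the data shown here, no measured pair tests this particular exchange. The measured steps all alter the group on the saturated chain carbon bound to an oxygen on the aromatic ring, and none of them moved the number beyond the scatter, which suggests that this region of the molecule can be changed without much effect on the read-out. The expected step is therefore a 1.1-fold lower number from compound 3 to compound 4 (0.03 log units; within the scatter), nothing beyond the scatter in either direction. Compound 4 is estimated at 8000 nM, with a range from 4000 nM to 16000 nM.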

Compound 4, half-maximal inhibitory concentration: 8900 nM
Estimate against measurement, compound 4: 1.1-fold (0.05 log units) below; low and high end bracket the measured number.
By their numbers in this assay, from the lowest: compounds 1, 2, 3 and 4 (each within the scatter of the next).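

In this assay, bromo in place of trifluoromethyl on an aromatic carbon ortho to a large group gives a 1.0-fold higher number from compound 3 to compound 4 (0.02 log units; within the scatter), the first step shown that alters this outer aromatic ring rather than the group on the saturated chain carbon, and it stays within the scatter. The new 2-bromobenzyl compound also stays within the scatter of the two compounds with a simpler group on that chain carbon, with a 1.7-fold higher number from compound 2 to compound 4 (0.23 log units; within the scatter) and a 2.0-fold higher number from compound 1 to compound 4 (0.30 log units; within the scatter), so the change at this aromatic carbon reveals no difference in the read-out. No measurement at hand explains why these compounds read alike.

From the compounds shown here alone, it remains open whether an amine or a carboxylic acid at this aromatic carbon would move the number beyond the scatter. The same question stands for a longer chain in place of the benzyl group.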